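Carboxy in place of hydroxy on compound 2

A few compounds are considered here, and "the series" means these few. Any claim that something is new, unique, unknown or untested is made for them only; others in the source may bear on it.

Measured so far in a functional assay on A-375 cells (Homo sapiens) for antiproliferative activity, read by MTT assay, with a stated time of 24 h (a higher number here means a weaker inhibitor, a lower number a stronger inhibitor), of this series:
compound 1 `CCc1ccc2nc(C(=O)Nc3c(F)cc(-c4cccc(F)c4)cc3F)c(C)c(O)c2c1` gives 8130 nM here
compound 2 `Cc1c(C(=O)Nc2ccc(-c3ccccc3)cc2)nc2ccccc2c1O` gives 75500 nM here

Compound 2 has the higher of the two numbers, and the gap down to compound 1 lies beyond the scatter. It is therefore the weaker inhibitor of this pair. The next compound to be read is compound 3 `Cc1c(C(=O)Nc2ccc(-c3ccccc3)cc2)nc2ccccc2c1C(=O)O`, which carries carboxy in place of hydroxy on an aromatic carbon, opposite the ring nitrogen (carboxy in place of hydroxy on an aromatic carbon). Among the compounds with values here, no measured pair isolates a change at this place, so the expectation rests on judgement alone. In this assay no step beyond the scatter is expected, with at most a slight fall in the number. The estimated size of a 1.5-fold lower number from compound 2 to compound 3 (0.18 log units; within the scatter) is accordingly small. Compound 3 is estimated at 50000 nM with an expected range from 10000 nM to 200000 nM as working bounds.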

Compound 3, half-maximal inhibitory concentration: > 100000 nM
Compound 3 gave a limit, no number; the forecaster's own chance of this, stated with the estimate: 20%; middle value at least 2.0-fold (0.30 log units) away from the limit.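

In this assay compound 3 gives > 100000 nM, which is a limit of the assay and not a number. Within the data shown here, this is the first reading of a change at this position, on an aromatic carbon opposite the ring nitrogen, and carboxy in place of hydroxy gives an at least 1.3-fold higher number from compound 2 to compound 3 (0.12 log units; that floor lies within the scatter), so the change shows no gain here, though only a floor for the step is known and that floor does not clear the scatter. The comparison therefore fixes a direction at best and no size: the limit of > 100000 nM in this assay, at which 1 of the 3 values shown sits.

Still open, as far as these compounds go, is how far the number rises with carboxy, which a reading inside the range of the assay would settle. Also open, from the compounds shown here alone, is whether a smaller or uncharged replacement at this position, such as a methoxy group, an amine or a methyl ester, would keep the number of compound 2.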